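The compounds below may be only part of what the source reports. "The series", "measured", "known", "first", "only" and "open" are said of these compounds alone.

In a functional assay on HeLa cells (Homo sapiens) for antiproliferative activity, read by MTT assay, with a stated time of 72 h (on this read-out higher numbers stand for weaker inhibition and lower numbers for stronger inhibition), compound 3 `O=C1COc2ccc(-c3cnc(Cl)c(NS(=O)(=O)c4ccc(F)cc4)c3)cc2N1`, which has hydrogen on an amide-type nitrogen in a ring, gives 15600 nM. Compound 2 `CC(C)N1C(=O)COc2ccc(-c3cnc(Cl)c(NS(=O)(=O)c4ccc(F)cc4)c3)cc21`, with isopropyl at that nitrogen, gives 5380 nM, the lower of the two numbers. Compound 1 `COc1cccc(N2C(=O)COc3ccc(-c4cnc(Cl)c(NS(=O)(=O)c5ccc(F)cc5)c4)cc32)c1`, with 3-methoxyphenyl at that nitrogen, reads > 40000 nM, and this value is a limit of the assay. The measured steps place the hydrogen compound in the middle of the three: an at least 2.5-fold lower number from compound 1 to compound 3 (0.40 log units; beyond the scatter), and a 2.9-fold higher number from compound 2 to compound 3 (0.46 log units; beyond the scatter). The widest gap is an at least 7.4-fold lower number from compound 1 to compound 2 (0.87 log units; beyond the scatter).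

Compound 4 `O=C1COc2ccc(-c3cnc(Cl)c(NS(=O)(=O)c4ccc(F)cc4)c3)cc2N1c1ccc(Cl)cc1` carries 4-chlorophenyl in place of that hydrogen: 4-chlorophenyl in place of hydrogen on an amide-type nitrogen in a ring. Going by the values given here, the entering group is one six-membered aromatic ring of carbon only, and compound 1 is the sole measured compound with such a ring at this nitrogen. Its step to the hydrogen compound is therefore the closest guide, read backwards, while the step from compound 2 says less about this change. The expectation rests on that single comparison, an at least 2.5-fold lower number from compound 1 to compound 3 (0.40 log units; beyond the scatter), so a higher number is expected for the new compound, and a reading at the limit of the assay is quite possible. The expected size of the change is a 2.2-fold higher number from compound 3 to compound 4 (0.35 log units; beyond the scatter). Compound 4 is estimated at 35000 nM, with an expected range from 12000 nM to 80000 nM.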

Compound 4, half-maximal inhibitory concentration: > 40000 nM
Compound 4: no number, only a limit (the forecaster's own chance of this, stated with the estimate: 55%); at least 1.1-fold (0.05 log units) between middle value and limit.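

In this assay, compound 4 reads as a limit of the assay and not as a number, so the poor result for compound 1 is no longer a single case: two different substituted phenyl groups on the amide-type nitrogen now both end at that limit. Putting 4-chlorophenyl on this nitrogen gives an at least 2.5-fold higher number from compound 3 to compound 4 (0.40 log units; beyond the scatter), and measured against the isopropyl compound the same group gives an at least 7.4-fold higher number from compound 2 to compound 4 (0.87 log units; beyond the scatter), so among the four compounds shown, the two with a six-membered aromatic ring of carbon only at this position lie on the weak side of both hydrogen and isopropyl. The step between compound 1 and compound 4 cannot be read, because both stand at the same end of the read-out: the limit of > 40000 nM in this assay, at which 2 of the 4 values shown sit.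

On these data alone, how far compound 1 and compound 4 differ therefore stays unknown, and so does whether the ring itself or its chlorine and methoxy substituents decide the outcome, which unsubstituted phenyl or benzyl at this nitrogen could begin to separate. Isopropyl is also the only alkyl group shown here, so it remains open whether methyl, a longer chain such as n-butyl, or a chain ending in an amine would follow compound 2.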